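Swapping the aromatic group of compound 3

The compounds below may be only part of what the source reports. "The series", "measured", "known", "first", "only" and "open" are said of these compounds alone.

Values in a functional assay on A549 cells (Homo sapiens) for antiproliferative activity, read by MTT assay, with a stated time of 48 h (a lower number here means a stronger inhibitor, a higher number a weaker inhibitor), are as follows:
Compound 1 `CCn1c(N)c(-c2nc3ccccc3[nH]2)c2nc(C#N)c(C#N)nc21` gives > 50000 nM as a limit
Compound 2 `CN(C)CCn1c(N)c(-c2nc3ccccc3s2)c2nc(C#N)c(C#N)nc21` gives > 50000 nM as a limit
Compound 3 `CN(C)CCCCn1c(N)c(-c2nc3ccccc3s2)c2nc(C#N)c(C#N)nc21` gives 35800 nM as a true number

Compound 3 alone carries a true number, and the rest of the set is held at the limit of > 50000 nM in this assay, at which 2 of the 3 values shown sit, and goes no further. Compound 4 `CN(C)CCCCn1c(N)c(-c2nc3ccccc3n2C)c2nc(C#N)c(C#N)nc21` keeps the 4-(dimethylamino)butyl group and changes one group, 1-methyl-1H-benzimidazol-2-yl in place of 1,3-benzothiazol-2-yl on an aromatic carbon with 1-methyl-1H-benzimidazol-2-yl in place of 1,3-benzothiazol-2-yl on an aromatic carbon, next to the ring atom that bears an amino group. For the measured compounds named here, the single measured step (an at least 1.3-fold lower number from compound 2 to compound 3 (0.14 log units; that floor lies within the scatter)) concerns the chain and not this group, so no measured step gives a size for the swap. Going by the values given here, the expectation therefore rests on compound 3 at 35800 nM as the only number. In this assay no step beyond the scatter is expected in either direction. The expected change is a 1.2-fold lower number from compound 3 to compound 4 (0.08 log units; within the scatter) and stays small. For compound 4 the estimate is 30000 nM with an expected range of 12000 nM to 50000 nM and a real chance of a limit instead of a true number.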

Compound 4, half-maximal inhibitory concentration: 6150 nM
For compound 4 the middle estimate is 4.9-fold (0.69 log units) above the measured one; measured number below the stated range.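

In this assay, the aromatic group on the carbon next to the ring atom that bears an amino group proves to matter: with the 4-(dimethylamino)butyl group held fixed, 1-methyl-1H-benzimidazol-2-yl in place of 1,3-benzothiazol-2-yl gives a 5.8-fold lower number from compound 3 to compound 4 (0.77 log units; beyond the scatter). For the compounds shown here, this is the first step that lies beyond the scatter, and the first to concern this position and not the chain. It also gives this position its first measured size, in a set where the other values are limits of the assay and not numbers: the limit of > 50000 nM in this assay, at which 2 of the 4 values shown sit.

The swap exchanges the ring sulfur for a nitrogen and adds a methyl group together, and the compounds shown do not separate these two changes. Also open, on these data alone, is how a 1-ethyl-1H-benzimidazol-2-yl group would read here, and whether the step holds with a longer chain such as 6-(dimethylamino)hexyl.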